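This account rests on a few compounds, and the source may have more. Where it says the series, first, only, none or still open, it means among the compounds named here.

Working notes on the series. Three members have numbers in a functional assay on Cortical neurone cells (Rattus norvegicus, strain Sprague-Dawley), read by MTT assay, with stated times of 24 h and 2 h, tested at 0.1 uM; on this read-out higher numbers stand for a stronger effect at the one concentration tested and lower numbers for a weaker effect. Compound 3 `COC(=O)C1=CNC(=O)[C@@H]2C(CO)=CC[C@H]12` is the smallest of them, and in this assay compound 3 gives 59%. Compound 1 `COC(=O)C1=CN(C)C(=O)[C@@H]2C(CN3CCN(Cc4ccc(C(F)(F)F)cc4)CC3)=CC[C@H]12` gives 63% in this assay. Compound 2 `COC(=O)C1=CN(C(C)C)C(=O)[C@@H]2C(CN3CCN(Cc4ccc([N+](=O)[O-])cc4)CC3)=CC[C@H]12` gives 67.1% in this assay, the highest of the three numbers; its gap to compound 1 and its gap to compound 3 both fall within the usual scatter of this read-out, so the three values read as one level and no order among them is claimed.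

Compound 4 `COC(=O)C1=CN(C(C)C)C(=O)[C@@H]2C(CN3CCN(Cc4cccc(C(F)(F)F)c4)CC3)=CC[C@H]12` has not yet been measured in this assay. It differs from compound 2 in one place: 3-(trifluoromethyl)phenyl in place of 4-nitrophenyl on a saturated chain carbon bound to an amine nitrogen in a ring. For the measured compounds named here, no pair of measured compounds differs only in this way, so the size of the step cannot be taken from measured data. The step from compound 2 to compound 4 in this assay is expected to be small, a number 2.1 percentage points lower from compound 2 to compound 4 (within the scatter), with no change beyond the scatter in either direction, because compound 1 gives 63% and compound 2 gives 67.1% in this assay although they differ in more than one place. Compound 4 is accordingly expected to give about 65% in this assay, with a range from 52% to 78%.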

Compound 4, a percentage reported as activity, at one concentration (the size of the read-out at that concentration, not a potency): 58.7%
Compound 4: middle estimate off by 6.3 percentage points, on the high side, within the range that was stated.
By their numbers in this assay, from the lowest: compounds 4, 3, 1 and 2 (each within the scatter of the next).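

For the compounds shown here, the first step at this position that can be read in one place is a number 8.4 percentage points lower from compound 2 to compound 4 (within the scatter) in this assay. On the core of compound 2, then, 3-(trifluoromethyl)phenyl can stand in place of 4-nitrophenyl on a saturated chain carbon bound to an amine nitrogen in a ring without a change beyond the scatter, even though the hydrogen-bond acceptors counted on the leaving group are absent from the entering one. No available evidence bears on this result.

On these data alone, whether a plain phenyl, a 4-aminophenyl or a pyridine ring in the same place would also stay within the scatter remains open, and so does whether any group at this position moves the read-out beyond it. Going by these compounds alone, the change from compound 2 to compound 4 alters both the substituent and its place on the aromatic ring, so these two contributions cannot be separated, and a read-out at a single concentration gives no potency for either compound.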